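Fluoro for trifluoromethyl on the pendant aryl ring

The compounds below may be only part of what the source reports. "The series", "measured", "known", "first", "only" and "open" are said of these compounds alone.

Measured compounds:
compound 1 `N#CCCc1ccc2nccc(SC3(C(=O)O)CCC3)c2c1`: 2760 nM
compound 2 `O=C(O)C1(Sc2ccnc3ccc(-c4ccc(C(F)(F)F)cc4)cc23)CCC1`: 1750 nM

Of the compounds shown here, two that share a core have been measured in an assay on HEK293 cells for inhibition of solute carrier family 22 member 12 (Homo sapiens), read by scintillation counting, with a stated time of 12 min; on this read-out higher numbers stand for weaker inhibition and lower numbers for stronger inhibition. Compound 1 gives 2760 nM and compound 2 gives 1750 nM. Compound 2 has the lowest of the two numbers, but the gap to compound 1 lies within the usual scatter of repeated measurements, so the two cannot be ranked against each other on this evidence.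

Compound 3 `O=C(O)C1(Sc2ccnc3ccc(-c4ccc(F)cc4)cc23)CCC1` is not yet measured. It differs from compound 2 in one place: fluoro in place of trifluoromethyl on an aromatic carbon. For the measured compounds named here, no pair of measured compounds differs in just one place, so there is no measured step to lean on for this change; the expectation below rests only on the values of compound 2 and compound 1 in this assay and on the size of the group that is exchanged.

For compound 3 a modest weakening is expected, a step of a 2.0-fold higher number from compound 2 to compound 3 (0.30 log units; within the scatter), which may well fall inside the scatter. Compound 3 is therefore estimated at 3500 nM, with a range from 1200 nM to 10000 nM, to be settled by the measurement that follows.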

Compound 3, half-maximal inhibitory concentration: 159 nM
For compound 3 the middle estimate is 22-fold (1.34 log units) above the measured one, and the stated range ends above it.
By their numbers in this assay, from the lowest: compound 3; then compounds 2 and 1 (each within the scatter of the next).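

In this assay, fluoro in place of trifluoromethyl, on an aromatic carbon para to a large group, gives an 11-fold lower number from compound 2 to compound 3 (1.04 log units; beyond the scatter), so this single position on the pendant ring can separate compounds well beyond the scatter. The group on the shared core also proves to matter in a way the first two compounds could not show: 4-fluorophenyl in place of 2-cyanoethyl gives a 17-fold lower number from compound 1 to compound 3 (1.24 log units; beyond the scatter). Having an aryl ring at that place is not sufficient in itself, since compound 2 carries one and gives 1750 nM, while compound 1 gives 2760 nM, and these two values lie within the scatter of each other; what sets compound 3 apart is the fluoro on that ring.

Nothing in the data at hand bears on why the exchange has so large an effect. As far as these compounds go, it remains open whether hydrogen, chloro, methoxy or an amine on the same aromatic carbon would give a number nearer that of compound 3 or that of compound 2, and whether the step would persist with a tetrazole in place of the carboxylic acid.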